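The source may report more compounds than this note shows. Statements on the series, on what has been measured and on what is new or still open speak of the compounds shown alone.

In a functional assay on KB cells (Homo sapiens) for antiproliferative activity, read by sulforhodamine B assay, with a stated time of 3 days (a higher number here means that more compound is needed for the effect, a lower number that less compound is needed), compound 3 `CCC1=C(O)c2c(oc(-c3cccc(F)c3)cc2=O)C(CC)(CC)C1=O` reads > 56.2 uM, which is a limit and not a number. Compound 1 `CCCc1ccc(-c2cc(=O)c3c(o2)C(CC)(CC)C(=O)C(CC)=C3O)cc1` also gives only a limit, > 53 uM. Compound 2 `CCC1=C(O)c2c(oc(-c3ccc(C(C)C)cc3)cc2=O)C(CC)(CC)C1=O` gives a real number, 8.13 uM. Compound 4 `CCC1=C(O)c2c(oc(-c3cc(C)c(C)cc3C)cc2=O)C(CC)(CC)C1=O` carries 2,4,5-trimethylphenyl in place of 3-fluorophenyl on an aromatic carbon. Going by the values given here, two measured steps bear on this change: an at least 6.5-fold lower number from compound 1 to compound 2 (0.81 log units; beyond the scatter), with isopropyl replacing propyl, and an at least 6.9-fold higher number from compound 2 to compound 3 (0.83 log units; beyond the scatter), with 3-fluorophenyl replacing 4-isopropylphenyl. Both lie beyond the scatter, yet only one of the three substituted phenyl groups measured so far gave a number. A modest move to a lower number is therefore expected. The estimated step is an at least 2.8-fold lower number from compound 3 to compound 4 (0.44 log units; beyond the scatter). For compound 4 the expected value is 20 uM, with an estimated range of 6 uM to 60 uM.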

Compound 4, concentration for half-maximal effect: 8.2 uM
Beside the measured number, compound 4's estimate is 2.4-fold (0.39 log units) above it; measured number inside the range.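

In this assay a second substituted phenyl group now gives a real number, and the steps to it from the two compounds that read only as limits are both large (an at least 6.8-fold lower number from compound 3 to compound 4 (0.83 log units; beyond the scatter)) and (an at least 6.4-fold lower number from compound 1 to compound 4 (0.81 log units; beyond the scatter)). The 2,4,5-trimethylphenyl group of compound 4 and the 4-isopropylphenyl group of compound 2 cannot be told apart (a 1.0-fold higher number from compound 2 to compound 4 (0.00 log units; within the scatter)). A number at this position is thus not tied to a single group, though 4-propylphenyl in compound 1 and 3-fluorophenyl in compound 3 go against any simple rule.

Which of the three methyl groups matter stays open. So does how a phenyl ring carrying an amine or a carboxylic acid would read.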